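A pyridinylmethylamino group replaces dimethylamino: what to expect

The source may report more compounds than this note shows. Statements on the series, on what has been measured and on what is new or still open speak of the compounds shown alone.

Of the compounds shown here, three with a shared core have been tested in an ADME assay on cells (Homo sapiens) for cytotoxicity, read by polymerase chain reaction, with a stated time of 3 days; a lower number here means that less compound is tolerated, a higher number that more compound is tolerated. Compound 1 `Nc1nc(Cl)c(-c2nccs2)c(N[C@@H]2C[C@H](CO)[C@@H](O)[C@H]2O)n1` gives only a limit in this assay, > 25000 nM. Compound 2 `CNc1ccc2nc(-c3c(Cl)nc(N)nc3N[C@@H]3C[C@H](CO)[C@@H](O)[C@H]3O)sc2c1` gives 6000 nM in this assay. Compound 3 `Cc1nc(N(C)C)nc(N[C@@H]2C[C@H](CO)[C@@H](O)[C@H]2O)c1-c1nc2ccccc2s1` gives 18000 nM in this assay, the higher of the two numbers that were actually reached, with compound 2 sitting beyond the scatter below it.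

Compound 4 `Cc1nc(NCc2ccncc2)nc(N[C@@H]2C[C@H](CO)[C@@H](O)[C@H]2O)c1-c1nc2ccccc2s1` differs from compound 3 in one place: ((pyridin-4-yl)methyl)amino in place of dimethylamino on an aromatic carbon. Among the compounds with values here, no measured pair here shows the effect of such a change, so the account rests on the values of compounds 1 to 3 alone, which all lie in the same upper region of this assay. The step from compound 3 to compound 4 in this assay is expected to be small, a 1.2-fold lower number from compound 3 to compound 4 (0.08 log units; within the scatter), and could fall within the scatter. Compound 4 is therefore estimated to give 15000 nM in this assay, with a range from 5000 nM to 40000 nM.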

Compound 4, half-maximal cytotoxic concentration: 7000 nM
The estimate for compound 4 lay 2.1-fold (0.33 log units) above the measured number, and the stated range covers the measured number.
By their numbers in this assay, from the lowest: compounds 2 and 4 (each within the scatter of the next); then compound 3. At a limit, above all of these: compound 1.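

In this assay, the aromatic carbon between two ring nitrogen atoms, para to the 1,3-benzothiazol-2-yl group, proves sensitive to what it carries: ((pyridin-4-yl)methyl)amino in place of dimethylamino gives a 2.6-fold lower number from compound 3 to compound 4 (0.41 log units; beyond the scatter). Within the data shown here, this is the first single-place step available, and although modest, it lies beyond the scatter, so the cells tolerate less of the compound with the larger group. Nothing in the data at hand accounts for this step.

The compounds shown leave open whether the step follows from the pyridine ring itself, since a benzylamino group or a (pyridin-3-yl)methylamino group would separate the ring from its nitrogen placement. On these data alone, it also remains open whether a small methylamino group or a morpholine at this carbon would stay level with compound 3.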